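Lengthening the Amide Chain of a Threonine Amide

The source may hold more compounds than are shown below. What is called first, only, known or untested is meant among the compounds shown, and "the series" means these compounds.

Three compounds here carry the same threonine-derived core, each with a long saturated chain attached through an amide. Compound 1 `CCCCCCCCCCCCCCCCCCNC(=O)[C@@H](N)[C@@H](C)O` bears the longest chain and a free amine; in a functional assay on MCF7 cells (Homo sapiens) for cytotoxicity, read by MTT assay, with a stated time of 48 h (a lower number here means a stronger inhibitor, a higher number a weaker inhibitor), compound 1 gives 27400 nM. Compound 3 `CCCCCCCCCCCCNC(=O)[C@@H](NC(=O)c1cc2ccccc2n1C)[C@@H](C)O` carries a shorter chain and an aromatic amide on the amine, and in this assay compound 3 gives 31300 nM. Compound 2 `C/C=C/C=C/C(=O)N[C@H](C(=O)NCCCCCCCC)[C@@H](C)O` has the shortest chain of the three together with a dienoyl amide on the amine; in this assay compound 2 gives 149000 nM, the highest number of the three and beyond the scatter from both others, so compound 2 is the weakest of the set.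

Compound 4 `C/C=C/C=C/C(=O)N[C@H](C(=O)NCCCCCCCCCCCC)[C@@H](C)O` keeps everything of compound 2 except one change: butyl in place of hydrogen on a saturated chain carbon, eight bonds along the chain from an amide-type nitrogen. This brings the chain of compound 4 to the same length as that of compound 3.

Going by the values given here, no directly comparable step has been measured, but the two compounds with longer chains, compound 1 and compound 3, both return lower numbers than compound 2. On that basis a modest drop in the number is expected from compound 2 to compound 4, amounting to a 3.0-fold lower number from compound 2 to compound 4 (0.47 log units; beyond the scatter), though the different caps make this uncertain. Compound 4 is therefore estimated at 50000 nM, with a likely range from 20000 nM to 120000 nM.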

Compound 4, half-maximal inhibitory concentration: 37100 nM
Compound 4: middle estimate off by 1.3-fold (0.13 log units), on the high side, within the range that was stated.
By their numbers in this assay, from the lowest: compounds 1, 3 and 4 (each within the scatter of the next); then compound 2.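

In this assay, going by these compounds alone, butyl in place of hydrogen on a saturated chain carbon, eight bonds along the chain from an amide-type nitrogen, gives the first comparison that changes chain length alone (a 4.0-fold lower number from compound 2 to compound 4 (0.60 log units; beyond the scatter)), so with the dienoyl amide held fixed this position responds to a longer chain. Penta-1,3-dien-1-yl in place of 1-methyl-1H-indol-2-yl on a carbonyl carbon gives a step that cannot be told apart from repeat-measurement noise (a 1.2-fold higher number from compound 3 to compound 4 (0.07 log units; within the scatter)), so at this shared chain length the two amide groups on the amine are not separated by this read-out. Nothing measured here explains why the number responds to the chain or why the swap leaves no clear mark.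

Within the data shown here, with only two chain lengths on the dienoyl amide, the trend has just two points, and ethyl or propyl in place of hydrogen at the same chain carbon would show whether the number falls gradually or only once the chain is long. A longer chain on the dienoyl amide, or a chain ending in an amine or a carboxylic acid, would show whether the number keeps falling or the end of the chain matters.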